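From Chloro to Amino on the Fused Ring of Compound 2

This account rests on a few compounds, and the source may have more. Where it says the series, first, only, none or still open, it means among the compounds named here.

Compound 2 `CCn1cc(-c2nc3ccc(Cl)cc3[nH]2)c(=O)c2cc(F)c(N3CCNCC3)cc21` is the point of reference. In a functional assay on HeLa cells (Homo sapiens) for cytotoxicity, read by sulforhodamine B assay, with a stated time of 48 h (on this read-out higher numbers stand for weaker inhibition of growth and lower numbers for stronger inhibition of growth), compound 2 gives 1200 nM, the lowest of the two numbers recorded. Compound 3 `CCn1cc(-c2nc3ccc([N+](=O)[O-])cc3[nH]2)c(=O)c2cc(F)c(N3CCNC(C)C3)c(F)c21` comes nearest, giving 1400 nM in this assay; the two values lie within the scatter of each other, so no order can be read between them. Compound 1 `CCn1cc(-c2nc3ccccc3[nH]2)c(=O)c2cc(F)c(N3CCNCC3)cc21` gives only a limit in this assay, > 10000 nM (the limit of > 10000 nM in this assay, at which 1 of the 3 values shown sits).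

Among the compounds with values here, the one measured step at the site in question runs from compound 1 to compound 2: an at least 8.3-fold lower number from compound 1 to compound 2 (0.92 log units; beyond the scatter). Within the data shown here, compound 3 differs from compound 2 in more than one place, so no single step can be drawn from it.

Compound 4 `CCn1cc(-c2nc3ccc(N)cc3[nH]2)c(=O)c2cc(F)c(N3CCNCC3)cc21` differs from compound 2 in one place: amino in place of chloro on an aromatic carbon. Among the measured compounds shown here, no measured step introduces amino anywhere in this set, so this change has no direct precedent. What the data do show is that hydrogen at this position sits at the limit while chloro gives a number. The step of a 2.9-fold higher number from compound 2 to compound 4 (0.46 log units; beyond the scatter) is expected to be modest and toward weaker inhibition of growth. The estimate for compound 4 is 3500 nM, with a range from 900 nM to 14000 nM.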

Compound 4, concentration for 50% growth inhibition: > 10000 nM
Compound 4: no number, only a limit; the forecaster's own chance of this, stated with the estimate: 25%; middle value at least 2.8-fold (0.45 log units) away from the limit.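

In this assay, amino in place of chloro gives an at least 8.3-fold higher number from compound 2 to compound 4 (0.92 log units; beyond the scatter), so the lower number reached with chloro at this position does not carry over to amino. Compound 4 gives > 10000 nM, which is a limit and not a number, and the step from hydrogen to amino cannot be read, with a limit at both of its ends. Of the groups shown on this aromatic carbon, only chloro gives a number, so the mere presence of a group here does not suffice, and the limit now holds more of the set: the limit of > 10000 nM in this assay, at which 2 of the 4 values shown sit.

The compounds shown leave open whether the lower number belongs to chloro alone or extends to other groups on this carbon, such as bromo, methyl or methoxy. Nitro appears only in compound 3, which differs from compound 2 in more than one place, so what nitro alone does at this position also remains unread.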